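Removing the Methoxy from Compound 3

This account rests on a few compounds, and the source may have more. Where it says the series, first, only, none or still open, it means among the compounds named here.

In a functional assay on MIA PaCa-2 cells (Homo sapiens) for cytotoxicity, read by WST assay, with a stated time of 48 h (a lower number here means a stronger inhibitor, a higher number a weaker inhibitor), compound 3 `COc1ccc2c(/C=C(\C#N)C(=O)c3c[nH]c4ccccc34)c[nH]c2c1` gives > 50000 nM, which is a limit of the assay and not a number. The series thus contains (the limit of > 50000 nM in this assay, at which 1 of the 3 values shown sits). In this assay, compound 1 `COc1ccc2[nH]cc(/C=C(\C#N)C(=O)c3c[nH]c4ccccc34)c2c1` gives 25100 nM, and compound 2 `N#C/C(=C\c1c[nH]c2cc(F)ccc12)C(=O)c1c[nH]c2ccccc12` gives 31600 nM. Compound 4 `N#C/C(=C\c1c[nH]c2ccccc12)C(=O)c1c[nH]c2ccccc12` has hydrogen in place of methoxy on an aromatic carbon. For the measured compounds named here, the one measured step touching this methoxy is an at least 1.5-fold higher number from compound 2 to compound 3 (0.19 log units; that floor lies within the scatter), where methoxy replaces fluoro. Compound 1 also carries a methoxy, yet it gives 25100 nM, which is a measured number. A modest move towards a lower number is therefore expected, namely an at least 1.6-fold lower number from compound 3 to compound 4 (0.22 log units; that floor lies within the scatter). For compound 4, the estimated value is 30000 nM, with an expected range of 15000 nM to 50000 nM.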

Compound 4, half-maximal inhibitory concentration: 36800 nM
Compound 4: middle estimate off by 1.2-fold (0.09 log units), on the low side; the measured number falls inside the stated range.
By their numbers in this assay, from the lowest: compounds 1, 2 and 4 (each within the scatter of the next). At a limit, above all of these: compound 3.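

Hydrogen in place of methoxy at this position gives an at least 1.3-fold lower number from compound 3 to compound 4 (0.13 log units; that floor lies within the scatter) in this assay. Hydrogen in place of fluoro gives a 1.2-fold higher number from compound 2 to compound 4 (0.07 log units; within the scatter), and hydrogen in place of the other methoxy gives a 1.5-fold higher number from compound 1 to compound 4 (0.17 log units; within the scatter). The parent with no substituent on this ring therefore cannot be told apart from the two measured substituted compounds.

Compound 3 remains a limit and not a number, so the full size of its step stays open: the limit of > 50000 nM in this assay, at which 1 of the 4 values shown sits.

From the compounds shown here alone, whether an amine or a carboxylic acid on this aromatic carbon would shift the number beyond the scatter also stays open.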